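Swapping a phenyl for a hexyl chain

The source may hold more compounds than are shown below. What is called first, only, known or untested is meant among the compounds shown, and "the series" means these compounds.

Compound 1 (`O=C1COc2ccccc2N1CCCn1cc(-c2ccccc2)nn1`): 370 nM
Compound 2 (`COc1ccc2cc(-c3cn(CCCN4C(=O)COc5ccccc54)nn3)ccc2c1`): 1300 nM

Both numbers come from a functional assay on IMR-32 cells (Homo sapiens) for antiproliferative activity, read by sulforhodamine B assay, with a stated time of 48 h; a lower number here means a stronger inhibitor of growth, a higher number a weaker inhibitor of growth. Compound 1 has the lower number of the two, which makes it the stronger inhibitor of growth, and the gap up to compound 2 lies beyond the usual scatter. Compound 3 (`CCCCCCc1cn(CCCN2C(=O)COc3ccccc32)nn1`) has not yet been measured. It keeps the core of compound 1 and alters a single group: hexyl in place of phenyl on an aromatic carbon. The incoming group is an open chain with no ring, while the outgoing one is an aromatic ring.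

For the measured compounds named here, no measured pair shows this change on its own, so the forecast rests on little. Going by the values given here, compound 1 (370 nM) holds the lowest number so far, and compound 2 (1300 nM) is the only other reading, so a rise seems likelier than a fall. The expected change is a moderate move toward a weaker inhibitor of growth in this assay (a 2.0-fold higher number from compound 1 to compound 3 (0.31 log units; beyond the scatter)), probably beyond the scatter. Compound 3 is estimated at (750 nM), with an expected range from (200 nM) to (3000 nM).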

Compound 3, concentration for 50% growth inhibition: 710 nM
The estimate for compound 3 lay 1.1-fold (0.02 log units) above the measured number; the measured number falls inside the stated range.
By their numbers in this assay, from the lowest: compounds 1, 3 and 2 (each within the scatter of the next, the first and the last beyond it).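

In this assay, placing hexyl instead of phenyl on this aromatic carbon of the five-membered ring gives a 1.9-fold higher number from compound 1 to compound 3 (0.28 log units; within the scatter), so this read-out does not separate the two compounds. At this position, then, an aromatic ring is not needed for a reading in this range: an open chain with no ring, holding the same count of 6 carbon atoms, does as well in this one assay. Neither group has hydrogen-bond donors, hydrogen-bond acceptors or a net charge, and nothing measured here explains why the two read alike.

From the compounds shown here alone, it remains open whether this position would accept groups unlike both of these, such as an amine or a carboxylic acid at the end of the chain, or whether a shorter propyl chain or a longer decyl chain would read the same. This is also a single swap on a single core, so it cannot show whether hexyl and phenyl would read alike with other groups elsewhere on the molecule.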